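Methoxymethyl at the Methyl Position of Compound 1

This account rests on a few compounds, and the source may have more. Where it says the series, first, only, none or still open, it means among the compounds named here.

Measured compounds in a functional assay on HeLa cells (Homo sapiens) for cytotoxicity, read by neutral red uptake, with a stated time of 3 days; on this read-out lower numbers stand for stronger inhibition and higher numbers for weaker inhibition:
compound 1 `Cc1c(F)c(N)c2c(=O)cc(-c3ccc(N)c(F)c3)oc2c1F`: > 100000 nM
compound 2 `Nc1ccc(-c2cc(=O)c3c(N)c(F)c(O)c(F)c3o2)cc1F`: > 100000 nM
compound 3 `CCC(=O)OCc1c(F)c(N)c2c(=O)cc(-c3ccc(N)c(F)c3)oc2c1F`: 69000 nM

Compound 1, with the structure `Cc1c(F)c(N)c2c(=O)cc(-c3ccc(N)c(F)c3)oc2c1F`, reaches only the limit of this assay; its value of > 100000 nM is a limit and not a number. Compound 2, with the structure `Nc1ccc(-c2cc(=O)c3c(N)c(F)c(O)c(F)c3o2)cc1F`, also gives only a limit, > 100000 nM. Going by the values given here, compound 3, with the structure `CCC(=O)OCc1c(F)c(N)c2c(=O)cc(-c3ccc(N)c(F)c3)oc2c1F`, is the one compound with a number here, 69000 nM. It sits at the limit of > 100000 nM in this assay, at which 2 of the 3 values shown sit, for two of the three compounds.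

The change to compound 4, with the structure `COCc1c(F)c(N)c2c(=O)cc(-c3ccc(N)c(F)c3)oc2c1F`, is methoxy in place of hydrogen on a saturated chain carbon bound to an aromatic carbon. Among the compounds with values here, the one step that bears on it touches the same saturated chain carbon: an at least 1.4-fold lower number from compound 1 to compound 3 (0.16 log units; that floor lies within the scatter). The step that the two limits leave unreadable from compound 1 to compound 2, by contrast, gives no readable size.

Since the step from compound 1 to compound 3 only reaches a floor that lies within the scatter, a step of similar size is expected for compound 4, if any: a number no higher from compound 1 to compound 4 (the limit leaves the size open). Compound 4 is therefore estimated at 100000 nM in this assay, with a range from 40000 nM to 250000 nM, and a fair chance that it, like compound 1, reports only a limit.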

Compound 4, half-maximal inhibitory concentration: > 100000 nM
Compound 4: a limit, no number; the forecaster's own chance of this, stated with the estimate: 55%; the middle value sits exactly at the limit.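

With methoxy on the saturated chain carbon bound to an aromatic carbon, compound 4 gives > 100000 nM in this assay, which is a limit and not a number. Compound 4 therefore joins the compounds for which this read-out gives no number, and the steps to it from compound 1 and compound 2 cannot be read: the limit of > 100000 nM in this assay, at which 3 of the 4 values shown sit.

Going by these compounds alone, the one readable step is an at least 1.4-fold higher number from compound 3 to compound 4 (0.16 log units; that floor lies within the scatter), so the methoxy of compound 4 and the propanoyloxy of compound 3, the only compound here with a number, are not separated beyond the scatter.

The compounds shown leave open whether an amine, a carboxylic acid or a longer ester chain on this saturated chain carbon would give a number clearly lower than that of compound 3. They also leave open how far compound 1, compound 2 and compound 4 lie beyond their limits, and so whether methoxy in place of hydrogen changes the read-out at all.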